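The source may report more compounds than this note shows. Statements on the series, on what has been measured and on what is new or still open speak of the compounds shown alone.

Measured in a functional assay on PC-3 cells (Homo sapiens) for cytotoxicity, read by MTT assay, with a stated time of 72 h; on this read-out lower numbers stand for stronger inhibition and higher numbers for weaker inhibition:
- compound 1 `O=C(/C=C/c1ccc([N+](=O)[O-])cc1)Nc1cc2c(Nc3ccc(F)c(Cl)c3)ncnc2cc1O[C@H]1CCOC1` gives 22800 nM
- compound 2 `COc1cc(/C=C/C(=O)Nc2cc3c(Nc4ccc(F)c(Cl)c4)ncnc3cc2O[C@H]2CCOC2)cc(OC)c1OC` gives 20500 nM
- compound 3 `N#Cc1ccc(/C=C/C(=O)Nc2cc3c(Nc4ccc(F)c(Cl)c4)ncnc3cc2O[C@H]2CCOC2)cc1` gives 36600 nM

On these numbers compound 3 is not separated from the other two. The relevant steps are a 1.6-fold higher number from compound 1 to compound 3 (0.21 log units; within the scatter) and a 1.8-fold higher number from compound 2 to compound 3 (0.25 log units; within the scatter), and neither lies beyond the scatter.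

The next compound is compound 4 `COc1ccc(/C=C/C(=O)Nc2cc3c(Nc4ccc(F)c(Cl)c4)ncnc3cc2O[C@H]2CCOC2)c(OC)c1OC`, which differs from compound 3 by 2,3,4-trimethoxyphenyl in place of 4-cyanophenyl on a double-bonded chain carbon bound to a double-bonded chain carbon. The nearest measured comparison is a 1.8-fold higher number from compound 2 to compound 3 (0.25 log units; within the scatter), which exchanges 4-cyanophenyl with 3,4,5-trimethoxyphenyl at the same place and here applies in reverse. In addition, a 1.1-fold lower number from compound 1 to compound 2 (0.05 log units; within the scatter) shows another exchange at this place that stays within the scatter. Among the compounds with values here, no measured compound carries 2,3,4-trimethoxyphenyl, so this transfer remains uncertain.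

In this assay no step beyond the scatter is expected, with at most a slight lean towards a lower number. The expected step is a 1.5-fold lower number from compound 3 to compound 4 (0.18 log units; within the scatter) as an estimate. For compound 4 the estimated value is 24000 nM, with an expected range from 11000 nM to 48000 nM.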

Compound 4, half-maximal inhibitory concentration: 7670 nM
The estimate for compound 4 lay 3.1-fold (0.50 log units) above the measured number, and the stated range ends above it.
By their numbers in this assay, from the lowest: compound 4; then compounds 2, 1 and 3 (each within the scatter of the next).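

In this assay the place on the double-bonded chain carbon now shows a real response to the aryl group: the earlier exchanges there all stayed within the scatter, whereas 2,3,4-trimethoxyphenyl gives a 4.8-fold lower number from compound 3 to compound 4 (0.68 log units; beyond the scatter) against 4-cyanophenyl and a 3.0-fold lower number from compound 1 to compound 4 (0.47 log units; beyond the scatter) against 4-nitrophenyl, both modest. The two trimethoxyphenyl groups are also not interchangeable: a 2.7-fold lower number from compound 2 to compound 4 (0.43 log units; beyond the scatter) separates them, so the arrangement of the methoxy groups matters here and not only their presence. Nothing available accounts for this difference. 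

As far as these compounds go, whether all the methoxy groups of compound 4 are needed stays open, as a single methoxy or a dimethoxyphenyl group would be the direct test. Also open, from the compounds shown here alone, is how an amine or a carboxylic acid on the phenyl ring at this place would compare with compound 4.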